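The source may report more compounds than this note shows. Statements on the series, on what has been measured and on what is new or still open speak of the compounds shown alone.

Compound 2 `COc1ccc(C(=O)/C=C/c2cc(-c3cc(OC)c(OC)c(OC)c3)n[nH]2)cc1OC` and compound 1 `COc1cc(-c2cc(/C=C/C(=O)c3ccc(N)cc3)[nH]n2)cc(OC)c1OC` share one core and differ only in the aryl group on the carbonyl carbon. In a functional assay on M14 cells (Homo sapiens) for cytotoxicity, read by sulforhodamine B assay, with a stated time of 48 h, tested at 100 uM (a higher number here means a weaker effect of the compound at the concentration tested, a lower number a stronger effect), compound 1 gives -78%. In this assay, going by the values given here, compound 2 gives -68%, the highest of the two numbers so far, with compound 1 nearest; the step of a number 10 percentage points higher from compound 1 to compound 2 (within the scatter) is the only measured one and lies within the scatter, so the two compounds cannot be ordered against each other.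

Compound 3 `COc1cc(-c2cc(/C=C/C(=O)c3ccc(F)c(F)c3)[nH]n2)cc(OC)c1OC` is not yet measured. The change from compound 2 is 3,4-difluorophenyl in place of 3,4-dimethoxyphenyl on a carbonyl carbon. The 3,4-dimethoxyphenyl leaves and 3,4-difluorophenyl enters, on the carbonyl carbon whose other neighbour is a double-bonded chain carbon.

Among the compounds with values here, the one measured step bears on this change only in that it also swaps the aryl group on the carbonyl carbon, and there it moved a number 10 percentage points higher from compound 1 to compound 2 (within the scatter), within the scatter. Within the data shown here, no measured step carries fluorine. The expected step is therefore a number 3 percentage points higher from compound 2 to compound 3 (within the scatter), no change beyond the scatter in either direction. Among the measured compounds shown here, the estimate for compound 3 in this assay is -65%, with a range from -85% to -35%, wide because only the step of a number 10 percentage points higher from compound 1 to compound 2 (within the scatter) anchors it.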

Compound 3, a percentage reported as activity, at one concentration (the size of the read-out at that concentration, not a potency): -38%
The estimate for compound 3 lay 27 percentage points below the measured number, within the range that was stated.
By their numbers in this assay, from the lowest: compounds 1 and 2 (each within the scatter of the next); then compound 3.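

The aryl group on the carbonyl carbon is not a silent position in this assay: 3,4-difluorophenyl in place of 3,4-dimethoxyphenyl gives a number 30 percentage points higher from compound 2 to compound 3 (beyond the scatter) and, against the other aryl group, 3,4-difluorophenyl in place of 4-aminophenyl gives a number 40 percentage points higher from compound 1 to compound 3 (beyond the scatter) in the same direction, whereas the earlier swap at this carbon stayed within the scatter. Both steps point to a weaker effect, which makes compound 3 the weakest of the three at the concentration tested, while compound 1 and compound 2 remain unseparated. No measurement available for this series accounts for the change.

From the compounds shown here alone, it remains open whether the shift follows the two fluorines together or a single one, and a 4-fluorophenyl group or an unsubstituted phenyl group on the carbonyl carbon would be needed to tell these apart. Going by these compounds, it is also open whether other groups at this carbon, such as a pyridine ring or a carboxylic acid on the phenyl ring, fall with compound 3 or with the other two, and a read-out at one concentration gives no potency for any of them.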